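The compounds below may be only part of what the source reports. "The series", "measured", "known", "first", "only" and "open" are said of these compounds alone.

Compound 1 `C=C(C)[C@@H]1CC=C(C)/C(=N/NC(=O)Nc2nnc(-c3ccc([N+](=O)[O-])cc3)o2)C1`: 300 mg/kg
Compound 2 `CC(C)=CC/C=C(/C)C/C=N/NC(=O)Nc1nnc(-c2ccc(Cl)cc2)o1`: 300 mg/kg

Both measured compounds were tested in a functional assay on the whole organism (strain Swiss albino) with Mus musculus as the target, with a stated time of 4 h; on this read-out higher numbers stand for an effect only at larger amounts of compound and lower numbers for an effect already at smaller amounts. Compound 1 gives 300 mg/kg there, and compound 2 gives 300 mg/kg, so compound 2 stands level with compound 1 at the digits shown; the two values lie within the scatter of each other, and no order between them can be read from these numbers.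

Compound 3 `CC(C)=CC/C=C(/C)C/C=N/NC(=O)Nc1nnc(-c2ccc([N+](=O)[O-])cc2)o1` has not yet been measured. It differs from compound 2 in one place: nitro in place of chloro on an aromatic carbon. A nitro group on a six-membered aromatic ring of carbon only is also present in compound 1, whose value in this assay is 300 mg/kg, the same figure at the printed digits as compound 2. On that basis no step beyond the scatter is expected in this assay from the change; the expected step is no change at the digits printed from compound 2 to compound 3 (within the scatter). Compound 3 is therefore estimated to give 300 mg/kg in this assay, within a range from 150 mg/kg to 600 mg/kg.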

Compound 3, minimum effective dose: 300 mg/kg
The estimate for compound 3 equals the measured number at the digits printed; the range from low to high includes it.
By their numbers in this assay, from the lowest: compounds 1, 2 and 3 (each within the scatter of the next).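

In this assay, within the data shown here, the exchange of 4-chlorophenyl for 4-nitrophenyl gives no change at the digits printed from compound 2 to compound 3 (within the scatter) and provides the first comparison here that isolates one change, since the two earlier compounds differ in more than one place. On an aromatic carbon para to a large group, the single chlorine atom can therefore be replaced by the three heavy atoms of nitro, which add two hydrogen-bond acceptors, without a step beyond the scatter in this read-out. No information is available that would explain this outcome.

The compounds shown leave open whether an amine, a carboxylic acid or a methoxy group at the same place would also stay within the scatter of compound 2, or whether any group there can move the value at all. They also leave open whether chloro in place of the nitro group of compound 1 would give the same result with that different side of the molecule, as this single step comes from the open-chain partner alone.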